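Fluoro for methyl on the aryl ring of compound 1

The compounds below may be only part of what the source reports. "The series", "measured", "known", "first", "only" and "open" are said of these compounds alone.

Measured compounds:
compound 1 `Cc1ccc(-c2nc3ccc(Br)cn3c2/C=N/O)cc1` — 20 mg/kg
compound 2 `COc1ccc(Cn2cc(CO/N=C/c3c(-c4ccc(C)cc4)nc4c(C)cccn34)nn2)cc1` — 40 mg/kg
compound 3 `Cc1ccc(-c2nc3ccc(Br)cn3c2/C=N/OCc2cn(Cc3ccc(C#N)cc3)nn2)cc1` — 40 mg/kg

In a functional assay on the whole organism (strain NMRI) with Mus musculus as the target, with a stated time of 0.5 h (on this read-out higher numbers stand for an effect only at larger amounts of compound and lower numbers for an effect already at smaller amounts), compound 1 gives the smallest of the three numbers, but compound 2 and compound 3 both lie within the scatter of it, so the three are not separated. No pair of these compounds differs in a single place, and no measured step is available to lean on.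

Compound 4 `O/N=C/c1c(-c2ccc(F)cc2)nc2ccc(Br)cn12` is not yet measured. It differs from compound 1 in one place: fluoro in place of methyl on an aromatic carbon. With no measured step of this kind in the series, the expected step in this assay is none beyond the scatter, in either direction. Compound 4 is therefore estimated at 20 mg/kg, range 10 mg/kg to 40 mg/kg, an expected step of no change at the digits printed from compound 1 to compound 4 (within the scatter).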

Compound 4, minimum effective dose: 40 mg/kg
The estimate for compound 4 lay 2.0-fold (0.30 log units) below the measured number; the measured number falls inside the stated range.
By their numbers in this assay, from the lowest: compounds 1, 2, 3 and 4 (each within the scatter of the next).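

In this assay, within the data shown here, fluoro in place of methyl on an aromatic carbon para to a large group gives a 2.0-fold higher number from compound 1 to compound 4 (0.30 log units; within the scatter), the first single-place step. At this position, the read-out does not separate methyl from fluoro. No measurement available here bears on the cause of this result. From the compounds shown here alone, whether an amine or a trifluoromethyl at the same position would separate from methyl remains open, as does whether the same exchange would read alike on compound 3.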